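The source may hold more compounds than are shown below. What is called first, only, known or untested is meant among the compounds shown, and "the series" means these compounds.

In an ADME assay on the whole organism with Oryza sativa as the target, tested at 0.1 uM (on this read-out lower numbers stand for a stronger effect and higher numbers for a weaker effect at the one concentration tested), compound 1 `CCCCCc1ccc(NC(=O)N[C@H](C)c2ccccc2)cc1` gives 100% and compound 2 `CC(=O)c1ccc(NC(=O)N[C@H](C)c2ccccc2)cc1` gives 96%. Going by the values given here, the one measured step, a number 4 percentage points lower from compound 1 to compound 2 (within the scatter), exchanges the group on the same aromatic carbon, so compound 2 sits within the scatter of compound 1 and no order holds between the two. Compound 3 `C[C@@H](NC(=O)Nc1ccc(I)cc1)c1ccccc1` differs from compound 2 by iodo in place of acetyl on an aromatic carbon. The step from compound 1 to compound 2 bears on this change and stayed within the scatter, so no step beyond the scatter is expected in this assay. Compound 3 is estimated at 97%, between 88% and 100%. The expected a number 1 percentage points higher from compound 2 to compound 3 (within the scatter) stays inside the scatter.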

Compound 3, a percentage reported as activity, at one concentration (the size of the read-out at that concentration, not a potency): 100%
Estimate against measurement, compound 3: 3 percentage points below; the range from low to high includes it.
By their numbers in this assay, from the lowest: compounds 2, 1 and 3 (each within the scatter of the next).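

Iodo in place of acetyl gives a number 4 percentage points higher from compound 2 to compound 3 (within the scatter), and iodo in place of pentyl gives no change at the digits printed from compound 1 to compound 3 (within the scatter), in this assay. On this aromatic carbon, para to a large group, three different groups now lie within the scatter of one another, even though iodo has no hydrogen-bond acceptor and acetyl has 1. No supporting data bear on why the read-out stays level here.

Still open, going by these compounds, is whether any group at this position moves the number beyond the scatter, for example an amine or a carboxylic acid.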